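A Second Fluorine on an Already Potent Modulator

The source may report more compounds than this note shows. Statements on the series, on what has been measured and on what is new or still open speak of the compounds shown alone.

Compound 1, `Cc1cccc(NC(=O)c2nn(C)c(-c3ccccc3)c2C)n1`, gives 4.4 nM in a functional assay on HEK293 cells for negative allosteric modulation of metabotropic glutamate receptor 5 (Homo sapiens), read by FLIPR and calcium flux; a higher number here means a weaker inhibitor, a lower number a stronger inhibitor.
Compound 2, `Cc1cccc(NC(=O)c2nn(C)c(-c3ccc(F)cc3)c2C)n1`, gives 1.1 nM in this assay.

For the measured compounds named here, of the two numbers so far, compound 2 holds the lower one, and its only neighbour is compound 1; that gap, a 4.0-fold lower number from compound 1 to compound 2 (0.60 log units; beyond the scatter), came from a fluoro in place of hydrogen on an aromatic carbon. Compound 3, `Cc1cccc(NC(=O)c2nn(C)c(-c3ccc(F)cc3F)c2C)n1`, takes one further step of that kind: fluoro in place of hydrogen on an aromatic carbon. The earlier step is the only measured one that bears on this change, and it was modest. A second fluoro on a ring that already carries one need not repeat that gain, and nothing has yet been measured for this exact change, so the expectation in this assay is a step of at most modest size, in either direction, quite possibly within the scatter. Compound 3 is therefore expected to give about 1 nM in this assay, within 0.4 nM to 3 nM, which means an expected step of a 1.1-fold lower number from compound 2 to compound 3 (0.04 log units; within the scatter).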

Compound 3, half-maximal inhibitory concentration: 3.7 nM
For compound 3 the middle estimate is 3.7-fold (0.57 log units) below the measured one; the measured number lies above the stated range.
By their numbers in this assay, from the lowest: compound 2; then compounds 3 and 1 (each within the scatter of the next).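

The gain from the first fluoro does not carry over to this new position: placing a second fluoro on the aromatic carbon ortho to a large group, which turns 4-fluorophenyl into 2,4-difluorophenyl, gives a 3.4-fold higher number from compound 2 to compound 3 (0.53 log units; beyond the scatter) in this assay. Measured against the plain phenyl, the two fluoro groups together give a 1.2-fold lower number from compound 1 to compound 3 (0.08 log units; within the scatter) and so leave no readable difference, which shows that the same swap of hydrogen for fluoro can matter in opposite directions depending on the ring carbon it occupies. Nothing available explains why this position behaves differently.

From the compounds shown here alone, whether a chloro, methyl or methoxy group on this same carbon would follow the fluoro remains open. So does the behaviour of 2-fluorophenyl, which would show this position's effect without the 4-fluoro group.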